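Pentyl in place of piperidin-1-yl: the step to compound 3

The compounds below may be only part of what the source reports. "The series", "measured", "known", "first", "only" and "open" are said of these compounds alone.

compound 1, `CN(C(=O)CNC(=O)CN1CCCCC1)c1ccc(Cl)cc1C(=O)c1ccccc1Cl`: > 100 mg/kg
compound 2, `CCCCCC(=O)NCC(=O)N(C)c1ccc(Cl)cc1C(=O)c1ccccc1Cl`: 90 mg/kg

Of the compounds shown here, two have been measured in a functional assay on the whole organism with Mus musculus as the target, in the rotarod test; a higher number here means that more compound is needed for the effect, a lower number that less compound is needed. For compound 1 the result is only a limit of the assay, > 100 mg/kg, so compound 1 stands at the limit of > 100 mg/kg in this assay, at which 1 of the 2 values shown sits, and no number is known for it. Compound 2 gives 90 mg/kg. Among the measured compounds shown here, the one measured step, butyl in place of piperidin-1-yl on a saturated chain carbon bound to a carbonyl carbon, is an at least 1.1-fold lower number from compound 1 to compound 2 (0.04 log units; that floor lies within the scatter), a step that is not resolved from the scatter.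

Compound 3, `CCCCCCC(=O)NCC(=O)N(C)c1ccc(Cl)cc1C(=O)c1ccccc1Cl`, has not been measured. It differs from compound 1 as follows: pentyl in place of piperidin-1-yl on a saturated chain carbon bound to a carbonyl carbon. This is the same kind of exchange as the measured step, with pentyl rather than butyl entering, so the step of an at least 1.2-fold lower number from compound 1 to compound 3 (0.09 log units; that floor lies within the scatter) is expected to be small, with no direction beyond the scatter. Compound 3 is therefore expected to give about 80 mg/kg, estimated between 40 mg/kg and 160 mg/kg.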

Compound 3, dose for half-maximal effect: 70 mg/kg
Compound 3: the middle estimate sits 1.1-fold (0.06 log units) above what was measured, within the range that was stated.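

In this assay, the second open-chain group in this place, on a saturated chain carbon bound to a carbonyl carbon, again gives only a floor: an at least 1.4-fold lower number from compound 1 to compound 3 (0.15 log units; that floor lies within the scatter). Among the compounds shown here, the first step with a number at both ends shows a 1.3-fold lower number from compound 2 to compound 3 (0.11 log units; within the scatter), so butyl and pentyl are not told apart here. Compound 1 stands at a limit, so both steps that start from it remain floors: the limit of > 100 mg/kg in this assay, at which 1 of the 3 values shown sits.

The compounds shown leave open how large the exchange of piperidin-1-yl really is, and whether its ring or its nitrogen matters, which a cyclohexyl group in the same place could separate. They also leave open whether a longer chain, or a carboxylic acid at the end of the chain, would move the number beyond the scatter.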